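Moving the Ring Nitrogen in a Series at the Limit

A few compounds are considered here, and "the series" means these few. Any claim that something is new, unique, unknown or untested is made for them only; others in the source may bear on it.

Compound 1 `CCOC(=O)c1ccc(-c2nn(Cc3ccccc3Cl)c3ccccc23)cc1` gives > 10000 nM in a functional assay on cells (Platelet, Homo sapiens) for inhibition (on this read-out higher numbers stand for weaker inhibition and lower numbers for stronger inhibition), which is a limit of the assay and not a number.
Compound 2 `CCOC(=O)c1ccc(-c2nn(Cc3ccccc3F)c3ccccc23)cc1` gives > 10000 nM in this assay, likewise only a limit.
Compound 3 `CCOC(=O)c1ccc(-c2nn(Cc3ccccn3)c3ccccc23)cc1` gives > 10000 nM in this assay, again only a limit.

Compound 1 therefore stands nowhere in particular among the numbers shown: its value is a limit, and the same holds for the two compounds that share its core. The steps a step that the two limits leave unreadable from compound 1 to compound 2, a step that the two limits leave unreadable from compound 1 to compound 3 and a step that the two limits leave unreadable from compound 2 to compound 3 cannot be sized because of the limit of > 10000 nM in this assay, at which 3 of the 3 values shown sit.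

Compound 4 `CCOC(=O)c1ccc(-c2nn(Cc3cccnc3)c3ccccc23)cc1` differs from compound 1 by pyridin-3-yl in place of 2-chlorophenyl on a saturated chain carbon bound to an aromatic nitrogen. The steps that come closest to this change are those from compound 1 and from compound 2 to compound 3, where pyridin-2-yl replaces a substituted phenyl on the same saturated chain carbon; neither step has a readable size, and all three measured compounds end at the limit. Among the measured compounds shown here, with no measured step showing any movement, the expected step that the limit leaves unreadable from compound 1 to compound 4 is no readable change from compound 1. Compound 4 is expected to give about 20000 nM in this assay, within a range from 8000 nM to 60000 nM, most probably reported again only as a limit.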

Compound 4, half-maximal inhibitory concentration: > 10000 nM
Compound 4: no number, only a limit (the forecaster's own chance of this, stated with the estimate: 80%); the middle value lies beyond the limit too.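

In this assay compound 4 gives > 10000 nM, which is a limit and not a number. Its steps from compound 1, compound 2 and compound 3 cannot be read because all four compounds end at the same limit: the limit of > 10000 nM in this assay, at which 4 of the 4 values shown sit.

The compounds shown leave open how strongly any of them inhibits, and whether 2-chlorophenyl, 2-fluorophenyl, pyridin-2-yl and pyridin-3-yl differ at all in this assay.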